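A few compounds are considered here, and "the series" means these few. Any claim that something is new, unique, unknown or untested is made for them only; others in the source may bear on it.

Working notes on the series. Compound 2 `c1cc(N2CCCC2)nc(Nc2ccc(Oc3ncnc4sccc34)cc2)n1` carries pyrrolidin-1-yl and an unsubstituted ring nitrogen; in a functional assay on A549 cells (Homo sapiens) for inhibition, read by MTT assay, with a stated time of 72 h, tested at 20 uM (a higher number here means more inhibition at the concentration tested (going by the name of the read-out), a lower number less inhibition), compound 2 gives 61%. Compound 1 `CN(c1ccc(Oc2ncnc3sccc23)cc1)c1nccc(N2CCCC2)n1` differs from compound 2 by methyl in place of hydrogen on a nitrogen on an aromatic ring; in this assay compound 1 gives 55.5%, and the step of a number 5.5 percentage points lower from compound 2 to compound 1 (within the scatter). Compound 3 `c1ccc2c(c1)CCN2c1ccnc(Nc2ccc(Oc3ncnc4sccc34)cc2)n1` differs from compound 2 by 2,3-dihydro-1H-indol-1-yl in place of pyrrolidin-1-yl on an aromatic carbon; in this assay compound 3 gives 2.81%, the step of a number 58.2 percentage points lower from compound 2 to compound 3 (beyond the scatter). Compound 3 therefore stands lowest of the three measured compounds, beyond the scatter from both compound 1 and compound 2.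

Compound 4 `CN(c1ccc(Oc2ncnc3sccc23)cc1)c1nccc(N2CCc3ccccc32)n1` has not been measured. It differs from compound 3 by methyl in place of hydrogen on a nitrogen on an aromatic ring, which is the same change as made from compound 2 to compound 1, where the step of a number 5.5 percentage points lower from compound 2 to compound 1 (within the scatter) stayed within the scatter; the cores of compound 3 and compound 4 relate to those of compound 2 and compound 1 by 2,3-dihydro-1H-indol-1-yl in place of pyrrolidin-1-yl on an aromatic carbon. Going by the values given here, since the only measured instance of this methylation left the read-out essentially unchanged, compound 4 is expected to sit near compound 3, with an expected step of a number 0.2 percentage points higher from compound 3 to compound 4 (within the scatter). The estimate for compound 4 in this assay is 3%, expected between -10% and 16%.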

Compound 4, a percentage reported as inhibition, at one concentration (the size of the read-out at that concentration, not a potency): 29.4%
The estimate for compound 4 lay 26.4 percentage points below the measured number; measured number outside the range, above it.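

In this assay, methyl in place of hydrogen on a nitrogen on an aromatic ring gives a number 26.6 percentage points higher from compound 3 to compound 4 (beyond the scatter), so the outcome of this change does not carry over from the core of compound 2 to the core of compound 3: the same change on two cores in this assay, a number 5.5 percentage points lower (within the scatter) from compound 2 to compound 1 and a number 26.6 percentage points higher (beyond the scatter) from compound 3 to compound 4, 32.1 percentage points apart, beyond the scatter of two such steps

Seen from the other change, 2,3-dihydro-1H-indol-1-yl in place of pyrrolidin-1-yl on an aromatic carbon gives a number 26.1 percentage points lower from compound 1 to compound 4 (beyond the scatter), the same direction as on the pair without methyl but a different size: the same change on two cores in this assay, a number 58.2 percentage points lower (beyond the scatter) from compound 2 to compound 3 and a number 26.1 percentage points lower (beyond the scatter) from compound 1 to compound 4, 32.1 percentage points apart, beyond the scatter of two such steps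

The four compounds show that these two changes do not add independently here, but they do not show why, and this single pair of cores gives no rule for any other core.

The compounds shown leave open whether a longer chain such as ethyl on that nitrogen follows methyl on either core. They also leave open whether a different cyclic amine, such as piperidin-1-yl or morpholin-4-yl, in place of pyrrolidin-1-yl would respond to methyl as compound 2 does or as compound 3 does.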